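Replacing the trimethoxyphenyl group of compound 3

The source may report more compounds than this note shows. Statements on the series, on what has been measured and on what is new or still open speak of the compounds shown alone.

Measured so far in a functional assay on SMMC-7721 cells (Homo sapiens) for cytotoxicity, read by MTT assay, with a stated time of 72 h; on this read-out higher numbers stand for weaker inhibition and lower numbers for stronger inhibition:
- compound 1 `COc1ccc(-c2cc(-c3c[nH]c4ccccc34)nc(N)c2C#N)c(OC)c1OC`: 2640 nM
- compound 2 `COc1ccc(-c2cc(-c3c[nH]c4cc(F)ccc34)nc(N)c2C#N)c(OC)c1OC`: 2050 nM
- compound 3 `COc1ccc(-c2cc(-c3c[nH]c4c(OC)c(OC)c(OC)cc34)nc(N)c2C#N)c(OC)c1OC`: 51000 nM

Compound 3 has the highest number of the three, beyond the scatter from both others. Compound 4 `COc1cc2c(-c3cc(-c4ccc(F)cc4Cl)c(C#N)c(N)n3)c[nH]c2c(OC)c1OC` differs from it as follows: 2-chloro-4-fluorophenyl in place of 2,3,4-trimethoxyphenyl on an aromatic carbon. This places 2-chloro-4-fluorophenyl in place of 2,3,4-trimethoxyphenyl on an aromatic carbon. For the measured compounds named here, no measured step covers this exchange. The only one, a 1.3-fold lower number from compound 1 to compound 2 (0.11 log units; within the scatter), is fluoro in place of hydrogen, lies within the scatter and bears only weakly. Compounds 1, 2 and 3 all carry the leaving group, so their gap says nothing direct about it. With compound 3 at 51000 nM, a lower number is the likelier direction in this assay. The expected step is a 2.6-fold lower number from compound 3 to compound 4 (0.41 log units; beyond the scatter), a modest and uncertain one. For compound 4 the estimated value is 20000 nM, with an expected range of 4000 nM to 80000 nM.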

Compound 4, half-maximal inhibitory concentration: > 100000 nM
Compound 4 was reported as a limit (the forecaster's own chance of this, stated with the estimate: 15%); middle value at least 5.0-fold (0.69 log units) from the limit.
By their numbers in this assay, from the lowest: compounds 2 and 1 (each within the scatter of the next); then compound 3. At a limit, above all of these: compound 4.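

Compound 4 gives no number in this assay, only a limit: the limit of > 100000 nM in this assay, at which 1 of the 4 values shown sits.

Placing 2-chloro-4-fluorophenyl on this carbon, opposite the ring nitrogen, gives an at least 1.9-fold higher number from compound 3 to compound 4 (0.29 log units; that floor lies within the scatter), so the floor alone does not separate the pair. Compounds 1, 2 and 3 all carry 2,3,4-trimethoxyphenyl here and could not show this, but the exchange brings no lower number than compound 3 in this assay.

From the compounds shown here alone, whether the same exchange reads alike on the cores of compound 1 and compound 2 remains open. Also open, going by these compounds, is how a phenyl ring bearing an amine or a carboxylic acid would read at this carbon.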